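Working notes: side-chain change after compound 2

A few compounds are considered here, and "the series" means these few. Any claim that something is new, unique, unknown or untested is made for them only; others in the source may bear on it.

Values in an in vitro ADME assay on microsomes from liver (Homo sapiens) for metabolic stability, using NADPH (a lower number here means slower removal, a higher number faster removal of the compound), so far
- Compound 1 `N#Cc1ccc2c(c1)cc(C(=O)NCCC(O)(C(F)(F)F)C(F)(F)F)n2Cc1cccc(OC(F)(F)F)c1` gives 20 mL.min-1.g-1
- Compound 2 `N#Cc1ccc2c(c1)cc(C(=O)NCCC1(O)CCC1)n2Cc1cccc(OC(F)(F)F)c1` gives 78 mL.min-1.g-1

Compound 2 holds the higher of these two numbers, and compound 1 sits beyond the scatter under it. Among the measured compounds shown here, the change leading to compound 3 `CC(O)C1(CNC(=O)c2cc3cc(C#N)ccc3n2Cc2cccc(OC(F)(F)F)c2)CCCC1` is a group of 8 heavy atoms (7 carbon, 1 oxygen; one five-membered non-aromatic ring of carbon only) in place of a group of 6 heavy atoms (5 carbon, 1 oxygen; one four-membered non-aromatic ring of carbon only), on a saturated chain carbon bound to an amide-type nitrogen and no measured pair tests it directly. For the measured compounds named here, only one measured step bears on it, namely a 3.9-fold higher number from compound 1 to compound 2 (0.59 log units; beyond the scatter) and this modest step did not vary ring size. Starting from compound 2 at 78 mL.min-1.g-1 a smaller step than that one is expected in this assay upward if anything, and it may stay within the scatter. The expected step is a 1.3-fold higher number from compound 2 to compound 3 (0.11 log units; within the scatter) and no larger one is assumed. For compound 3 the estimated value is 100 mL.min-1.g-1 (expected range 50 mL.min-1.g-1 to 200 mL.min-1.g-1).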

Compound 3, intrinsic clearance in microsomes: 505 mL.min-1.g-1
Estimate against measurement, compound 3: 5.1-fold (0.70 log units) below, outside the stated range (above it).
By their numbers in this assay, from the lowest: compound 1; then compound 2; then compound 3.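

In this assay, the side chain on the saturated carbon bound to the amide-type nitrogen moves the clearance further than compounds 1 and 2 alone showed, even between two carbon-only ring groups that both keep one hydroxyl. The group with the five-membered ring in place of (1-hydroxycyclobutyl)methyl gives a 6.5-fold higher number from compound 2 to compound 3 (0.81 log units; beyond the scatter) and, against the fluorinated side chain, a 25-fold higher number from compound 1 to compound 3 (1.40 log units; beyond the scatter) so that this one position now spans a large range with the shared core unchanged. Nothing available explains the rise.

The compounds shown do not separate ring size from the other differences between the two groups, which change together here. Going by these compounds, how a side chain ending in an amine or a carboxylic acid, or the five-membered ring group carrying trifluoromethyl, would stand in this assay remains open.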